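This account rests on a few compounds, and the source may have more. Where it says the series, first, only, none or still open, it means among the compounds named here.

Compound 1 `Cc1ccc(C)c(NC(=O)CSc2nnc(-c3ccoc3C)n2Cc2ccco2)c1`: in a functional assay on CHO cells for antagonist activity at Orexin receptor type 2 (Homo sapiens), read by FLIPR and calcium flux (a higher number here means a weaker inhibitor, a lower number a stronger inhibitor), compound 1 gives 398 nM.
Compound 2 `Cc1cccc(NC(=O)CSc2nnc(-c3ccoc3C)n2Cc2ccco2)c1C`: in this assay compound 2 reaches only the limit > 15800 nM, a boundary of the measurement rather than a number.
Compound 3 `COc1ccccc1NC(=O)CSc1nnc(-c2ccoc2C)n1Cc1ccco1`: in this assay compound 3 gives 501 nM.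

Compound 3 stands close to compound 1, with a 1.3-fold higher number from compound 1 to compound 3 (0.10 log units; within the scatter). Compound 2 sits at the limit of > 15800 nM in this assay, at which 1 of the 3 values shown sits, so the steps of an at least 39-fold higher number from compound 1 to compound 2 (1.59 log units; beyond the scatter) and an at least 31-fold lower number from compound 2 to compound 3 (1.49 log units; beyond the scatter) are both large. All three differ only in the ring on the amide-type nitrogen. Compound 4 `CC(=O)c1ccc(NC(=O)CSc2nnc(-c3ccoc3C)n2Cc2ccco2)cc1` carries the change (4-acetylphenyl in place of 2-methoxyphenyl on an amide-type nitrogen). The measured steps show that altering this ring can leave the number untouched or push it past the limit, and a 4-acetylphenyl matches neither case. A moderate weakening is therefore expected, a 5.0-fold higher number from compound 3 to compound 4 (0.70 log units; beyond the scatter), giving compound 4 an expected 2500 nM, between 500 nM and 16000 nM.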

Compound 4, inhibition constant: 31.6 nM
Compound 4: the middle estimate sits 79-fold (1.90 log units) above what was measured, and the stated range ends above it.
By their numbers in this assay, from the lowest: compound 4; then compounds 1 and 3 (each within the scatter of the next). At a limit, above all of these: compound 2.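

Changing the ring on the amide-type nitrogen can strengthen inhibition as well as leave it unchanged or lose it, as 4-acetylphenyl gives a 16-fold lower number from compound 3 to compound 4 (1.20 log units; beyond the scatter) and a 13-fold lower number from compound 1 to compound 4 (1.10 log units; beyond the scatter), together with an at least 500-fold lower number from compound 2 to compound 4 (2.69 log units; beyond the scatter). Compound 2 stands at a limit, not a number: the limit of > 15800 nM in this assay, at which 1 of the 4 values shown sits. Compound 4 is thus the only compound shown whose number lies lower than those of compounds 1 and 3 beyond the scatter.

The compounds shown leave open whether the acetyl group itself or its place on the ring carries this gain. A plain phenyl or a 4-methoxyphenyl on the same nitrogen would help separate the two.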